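Changing the Aryl Group on the Amine Nitrogen

The source may hold more compounds than are shown below. What is called first, only, known or untested is meant among the compounds shown, and "the series" means these compounds.

In a functional assay on KB cells (Homo sapiens) for cytotoxicity, read by sulforhodamine B assay (a lower number here means a stronger inhibitor, a higher number a weaker inhibitor), compound 1 `C=C1[C@@H](OC(C)=O)C[C@@H]2[C@](C)(COC=O)[C@H](OC(C)=O)CC[C@@]2(C)[C@@H]1C[C@@H](Nc1ccccc1F)C1=CCOC1=O` gives 29000 nM and compound 3 `C=C1[C@@H](OC(C)=O)C[C@@H]2[C@](C)(COC=O)[C@H](OC(C)=O)CC[C@@]2(C)[C@@H]1C[C@@H](Nc1ccc(Br)cc1)C1=CCOC1=O` gives 24000 nM, so compound 3 stands within the scatter of compound 1. Compound 2 `C=C1[C@@H](OC(C)=O)C[C@@H]2[C@](C)(COC=O)[C@H](OC(C)=O)CC[C@@]2(C)[C@@H]1C[C@@H](Nc1ccc(OC)c(OC)c1)C1=CCOC1=O` returns only a limit of the assay, > 50000 nM.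

Compound 4 `C=C1[C@@H](OC(C)=O)C[C@@H]2[C@](C)(COC=O)[C@H](OC(C)=O)CC[C@@]2(C)[C@@H]1C[C@@H](Nc1cccc2ccccc12)C1=CCOC1=O` carries naphthalen-1-yl in place of 4-bromophenyl on an amine nitrogen.

Three measured swaps on this nitrogen bear on the change. They are a 1.2-fold lower number from compound 1 to compound 3 (0.08 log units; within the scatter), an at least 1.7-fold higher number from compound 1 to compound 2 (0.23 log units; that floor lies within the scatter) and an at least 2.0-fold lower number from compound 2 to compound 3 (0.31 log units; beyond the scatter), and only the last passes the scatter. The expected step is therefore small and not beyond the scatter: a 1.1-fold lower number from compound 3 to compound 4 (0.04 log units; within the scatter). For compound 4 the estimated value in this assay is 22000 nM, with an expected range of 10000 nM to 50000 nM.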

Compound 4, half-maximal inhibitory concentration: 32300 nM
Beside the measured number, compound 4's estimate is 1.5-fold (0.17 log units) below it; the range from low to high includes it.
By their numbers in this assay, from the lowest: compounds 3, 1 and 4 (each within the scatter of the next). At a limit, above all of these: compound 2.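

In this assay, naphthalen-1-yl, with its second six-membered aromatic ring on this nitrogen, stays within the scatter of both 4-bromophenyl and 2-fluorophenyl: there is a 1.3-fold higher number from compound 3 to compound 4 (0.13 log units; within the scatter) and a 1.1-fold higher number from compound 1 to compound 4 (0.05 log units; within the scatter). The remaining step, an at least 1.5-fold lower number from compound 2 to compound 4 (0.18 log units; that floor lies within the scatter), is only a floor and sets no firm order. Compound 2 remains a limit of the assay: the limit of > 50000 nM in this assay, at which 1 of the 4 values shown sits.

On these data alone, whether a pyridine ring, a cyclohexyl group or a carboxylic acid on the aryl ring would carry the number beyond the scatter of these values stays open.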